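A few compounds are considered here, and "the series" means these few. Any claim that something is new, unique, unknown or untested is made for them only; others in the source may bear on it.

Compound 1 `CC1(C)CC(=O)C2=C(C1)NC(c1ccccc1)=CC2c1ccccc1`: "not active" (no number reported)
Compound 2 `CCOC(=O)C1=CC(c2ccc(F)cc2)C2=C(CC(C)(C)CC2=O)N1`: "not active" (no number reported)
Compound 3 `CC1(C)CC(=O)C2=C(C1)NC(c1ccccc1)=CC2c1ccc(Cl)cc1`: 7.16%

In an assay on isolated protein for inhibition of glucose-6-phosphatase catalytic subunit 1 (Homo sapiens), read by inositol phosphate accumulation, with a stated time of 30 min, tested at 100 uM (on this read-out higher numbers stand for more inhibition at the one concentration tested (going by the name of the read-out) and lower numbers for less inhibition), compound 1 gives "not active" (no number reported) and compound 2 gives "not active" (no number reported). Compound 3 gives 7.16%, the only figure among the three compounds and a small one. Compound 4 `CC1(C)CC(=O)C2=C(C1)NC(c1ccccc1)=CC2c1ccc(F)cc1` differs from compound 3 by fluoro in place of chloro on an aromatic carbon. Among the compounds with values here, no comparison between two measured compounds covers this change, so its effect in this assay has no precedent here. Because compound 3 stands at 7.16%, little room remains beneath it, and the expected step is a number 2.2 percentage points lower from compound 3 to compound 4 (within the scatter), within the scatter. Compound 4 is estimated at 5%, with a range from 0% to 15%.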

Compound 4, a percentage reported as inhibition, at one concentration (the size of the read-out at that concentration, not a potency): 7.38%
The estimate for compound 4 lay 2.4 percentage points below the measured number; the range from low to high includes it.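

In this assay, within the data shown here, the change from 4-chlorophenyl to 4-fluorophenyl gives a number 0.2 percentage points higher from compound 3 to compound 4 (within the scatter) and is the first comparison at this position; the two halogens cannot be told apart here. Compound 1, which carries neither halogen at this place, gives "not active" (no number reported) without a number, so only the compounds with a halogen here have a figure to compare. Nothing measured here explains the result.

From the compounds shown here alone, whether an amine, a carboxylic acid or a methoxy group on this aromatic carbon would lift inhibition clear of these small figures remains open. So does whether any other place on the shared core matters more.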